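Phenyl on the Aromatic Nitrogen: An Expected Limit for Compound 3

The compounds below may be only part of what the source reports. "The series", "measured", "known", "first", "only" and "open" are said of these compounds alone.

Compound 1 `CCOC(=O)C(=O)CC(=O)/C=C/c1cn(CCC(C)C)c2ccccc12`: > 40 uM
Compound 2 `C=C(C)Cn1cc(/C=C/C(=O)CC(=O)C(=O)OCC)c2ccccc21`: > 40 uM

In an assay on isolated protein for inhibition of DNA nucleotidylexotransferase (Homo sapiens), read by scintillation counting, with a stated time of 10 min (a lower number here means a stronger inhibitor, a higher number a weaker inhibitor), compound 1 gives only a limit, > 40 uM. Compound 2 likewise gives only a limit, > 40 uM. The step that the two limits leave unreadable from compound 1 to compound 2 cannot be read because both values sit at the limit of > 40 uM in this assay, at which 2 of the 2 values shown sit. Compound 3 `CCOC(=O)C(=O)CC(=O)/C=C/c1cn(-c2ccccc2)c2ccccc12` differs from compound 2 by phenyl in place of 2-methylprop-2-en-1-yl on an aromatic nitrogen. No readable measured step bears on this change, so compound 3 is expected to stay at the limit too. The expected step that the limit leaves unreadable from compound 2 to compound 3 therefore amounts to no change beyond the scatter. Compound 3 is estimated at 60 uM, within 20 uM to 200 uM.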

Compound 3, concentration for 50% inhibition: > 40 uM
Compound 3 ended at the assay's limit; the forecaster's own chance of this, stated with the estimate: 80%; the middle value is on the limit's open side.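

No step can be read among compound 1, compound 2 and compound 3, since each gives only a limit: the limit of > 40 uM in this assay, at which 3 of the 3 values shown sit. Going by these compounds, whether any group on the aromatic nitrogen can bring a value off this limit remains open.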